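Working notes: from compound 2 to compound 3

The compounds below may be only part of what the source reports. "The series", "measured", "known", "first", "only" and "open" are said of these compounds alone.

- compound 1 `CCn1c(C(=O)NCCCN(C)C)ccc1C(CC)(CC)c1ccc(OCC(=O)C(C)(C)C)c(C)c1` gives 1600 nM
- compound 2 `CCn1c(C(=O)N(C)CCC#N)ccc1C(CC)(CC)c1ccc(OCC(O)C(C)(C)C)c(C)c1` gives 1700 nM

Going by the values given here, both numbers come from a functional assay on PC-3 cells (Homo sapiens), read by MTT assay, with a stated time of 48 h (a lower number here means a stronger inhibitor, a higher number a weaker inhibitor), and are the only measurements so far. Compound 2 stands at 1700 nM and compound 1 at 1600 nM, so the two lie within the scatter of each other and set no order. Their structures differ in more than one place, so no single change can be read from this pair.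

Compound 3 `CCn1c(C(=O)Oc2ccc(CCO)cc2)ccc1C(CC)(CC)c1ccc(OCC(O)C(C)(C)C)c(C)c1` has not yet been measured. Its difference from compound 2 is a group of 10 heavy atoms (8 carbon, 2 oxygen; one six-membered aromatic ring of carbon only) in place of a group of 6 heavy atoms (4 carbon, 2 nitrogen; no ring), on a carbonyl carbon, which places a group of 10 heavy atoms with one six-membered aromatic ring of carbon only on the carbonyl carbon. Among the compounds with values here, no measured step shows what such a replacement does, so no direction can be argued from the data and the range stays wide. The expected change is a 1.1-fold lower number from compound 2 to compound 3 (0.05 log units; within the scatter) and this is none beyond the scatter. The estimated value for compound 3 is 1500 nM with an expected range from 400 nM to 6000 nM in this series.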

Compound 3, half-maximal inhibitory concentration: 6300 nM
Beside the measured number, compound 3's estimate is 4.2-fold (0.62 log units) below it; measured number outside the range, above it.
By their numbers in this assay, from the lowest: compounds 1 and 2 (each within the scatter of the next); then compound 3.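

In this assay, the step at this position is a 3.7-fold higher number from compound 2 to compound 3 (0.57 log units; beyond the scatter), with the group of 10 heavy atoms and its six-membered aromatic ring of carbon only in place of (2-cyanoethyl)(methyl)amino on the carbonyl carbon. Going by these compounds alone, this is the first single-place comparison, and it shows that the group on this carbonyl carbon can move the number beyond the scatter, which compound 1 and compound 2 could not show because they differ in more than one place. No measurement at hand bears on the reason for this rise, so the step stands as an observation only.

A single step leaves open which part of the entering group goes with the higher number: the six-membered aromatic ring, the hydrogen-bond donor, or the oxygen atoms it brings to the carbonyl carbon. The compounds shown also leave open how a piperidine or a carboxylic acid at the same carbonyl carbon would compare on the core of compound 2, and whether this step would hold with the ketone side chain of compound 1.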